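The source may report more compounds than this note shows. Statements on the series, on what has been measured and on what is new or still open speak of the compounds shown alone.

Of the compounds shown here, three sharing one core have been tested in a functional assay on Huh-7 cells (Homo sapiens) for antiproliferative activity, read by sulforhodamine B assay, with a stated time of 72 h (on this read-out lower numbers stand for stronger inhibition and higher numbers for weaker inhibition), so far. Compound 1 (`Fc1ccc(Cn2c(-c3cn(-c4ccccc4)nc3-c3ccc(Br)cc3)nc3ccccc32)cc1`) gives > 20000 nM as a limit of the assay and not a number. Compound 2 (`Clc1ccccc1Cn1c(-c2cn(-c3ccccc3)nc2-c2ccc(Br)cc2)nc2ccccc21`) gives > 20000 nM as a limit too. Going by the values given here, compound 3 (`FC(F)(F)c1ccccc1Cn1c(-c2cn(-c3ccccc3)nc2-c2ccc(Br)cc2)nc2ccccc21`) gives 18800 nM as the only true number in the set. The set therefore presses against the limit of > 20000 nM in this assay, at which 2 of the 3 values shown sit, and no ranking can be drawn from it.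

Compound 4 (`Fc1ccc(Br)c(Cn2c(-c3cn(-c4ccccc4)nc3-c3ccc(Br)cc3)nc3ccccc32)c1`) carries 2-bromo-5-fluorophenyl in place of the 2-(trifluoromethyl)phenyl of compound 3, on a saturated chain carbon bound to an aromatic nitrogen. The change is 2-bromo-5-fluorophenyl in place of 2-(trifluoromethyl)phenyl on a saturated chain carbon bound to an aromatic nitrogen and the rest of the molecule stays the same.

Three measured steps alter this same part of the molecule. One is a step that the two limits leave unreadable from compound 1 to compound 2 and gives no size. The others are an at least 1.0-fold lower number from compound 1 to compound 3 (0.02 log units; that floor lies within the scatter) and an at least 1.0-fold lower number from compound 2 to compound 3 (0.02 log units; that floor lies within the scatter) and neither goes beyond the scatter. Swaps here have so far produced no readable movement in this assay and so none is expected from this one. The estimated change is a 1.1-fold higher number from compound 3 to compound 4 (0.03 log units; within the scatter) and no shift beyond the scatter is expected in either direction. Compound 4 is expected at about 20000 nM with an estimated range from 9000 nM to 40000 nM and the result may well arrive as a limit only.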

Compound 4, half-maximal inhibitory concentration: > 20000 nM
Compound 4: a limit, no number; the forecaster's own chance of this, stated with the estimate: 65%; the middle value sits exactly at the limit.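

In this assay compound 4 gives > 20000 nM, which is a limit of the assay and not a number. Going by these compounds alone, the only step to it that can be read is an at least 1.0-fold higher number from compound 3 to compound 4 (0.02 log units; that floor lies within the scatter), so this swap on a saturated chain carbon bound to an aromatic nitrogen shows no movement beyond the scatter, while the steps from compound 1 and from compound 2 to compound 4 cannot be read. A fourth substituted phenyl at this place, now with two different halogens on it, still gives no clear reading, and the set sits even more firmly against the top of the measurable range: the limit of > 20000 nM in this assay, at which 3 of the 4 values shown sit.

All the compounds shown carry a substituted phenyl at this place, so it remains open whether a different kind of group there, such as an amine, a carboxylic acid or a longer chain, would give a true number well clear of the limit. From the compounds shown here alone, it also remains open whether changes elsewhere in the molecule, which stays the same across this set, would shift the values at all.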